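The compounds below may be only part of what the source reports. "The series", "measured", "known", "first", "only" and "open" are said of these compounds alone.

Compound 1 `COC(=O)c1cccc(NC(=O)c2cccc(-c3cc(C(=O)Nc4ccncc4F)ccc3CN)c2)c1F`: 1.2 nM in an assay on cells for inhibition of Rho-associated protein kinase 2 (Homo sapiens), read by radiometric assay and 33P incorporation, in the presence of a further agent that is not named here; a lower number here means a stronger inhibitor, a higher number a weaker inhibitor. Compound 2 `CC(C)OC(=O)c1cccc(NC(=O)c2cccc(-c3cc(C(=O)Nc4ccncc4F)ccc3CN)c2)c1`: 7 nM in this assay.

Among the compounds with values here, compound 2 gives the highest of the two numbers in this assay; its only neighbour is compound 1, separated by a 5.8-fold higher number from compound 1 to compound 2 (0.77 log units; beyond the scatter). Compound 3 `NCc1ccc(C(=O)Nc2ccncc2F)cc1-c1cccc(C(=O)Nc2cccc(C(=O)O)c2F)c1` is not yet measured; it differs from compound 2 by 3-carboxy-2-fluorophenyl in place of 3-(isopropoxycarbonyl)phenyl on an amide-type nitrogen. Within the data shown here, only the step from compound 1 to compound 2 bears on this change, and only in part: that step set the fluorine together with the methoxycarbonyl against the isopropoxycarbonyl, and no measured pair sets a carboxy group against an ester. A step of a 1.8-fold lower number from compound 2 to compound 3 (0.24 log units; within the scatter) toward a lower number is expected, with wide uncertainty. Compound 3 is expected to give 4 nM in this assay, within 1 nM to 25 nM.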

Compound 3, half-maximal inhibitory concentration: 3.5 nM
The estimate for compound 3 lay 1.1-fold (0.06 log units) above the measured number; measured number inside the range.
By their numbers in this assay, from the lowest: compound 1; then compounds 3 and 2 (each within the scatter of the next).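

Within the data shown here, with the fluorine held in place, compound 1 and compound 3 give the first direct comparison of ester and acid in this assay, where hydrogen in place of methyl on an oxygen next to a carbonyl group gives a 2.9-fold higher number from compound 1 to compound 3 (0.46 log units; beyond the scatter). Replacing the whole group on the amide-type nitrogen gives only a 2.0-fold lower number from compound 2 to compound 3 (0.30 log units; within the scatter), so a carboxy group remains compatible with a low number at this position. No measurement here accounts for either step. Among these compounds, the separate contribution of the fluorine remains open, as no pair changes it alone. Also open, going by these compounds, is how a primary amide or a tetrazole would compare with the carboxylic acid.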